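A few compounds are considered here, and "the series" means these few. Any claim that something is new, unique, unknown or untested is made for them only; others in the source may bear on it.

Compound 1 `COc1cc(NC(=O)/C=C/c2cccc(OCc3ccccc3)c2)cc(OC)c1OC`: 8500 nM
Compound 2 `C=C(Br)C(=O)Nc1cccc(/C=C/C(=O)Nc2ccc(F)cc2)c1`: 8400 nM

Both compounds were tested in a functional assay on SEM cells (Homo sapiens) for inhibition, read by MTT assay, with a stated time of 72 h; on this read-out higher numbers stand for weaker inhibition and lower numbers for stronger inhibition. Their values lie within the usual scatter of each other, so compound 2 stands level with compound 1. Compound 3 `C=C(Br)C(=O)Nc1cccc(/C=C/C(=O)Nc2ccc(SC(F)(F)F)cc2)c1` has (trifluoromethyl)sulfanyl in place of fluoro on an aromatic carbon, para to a large group: (trifluoromethyl)sulfanyl in place of fluoro on an aromatic carbon. Among the measured compounds shown here, no measured pair shows this change, so any forecast in this assay is loose. A moderate move toward stronger inhibition is expected, as the estimated 3.4-fold lower number from compound 2 to compound 3 (0.53 log units; beyond the scatter) shows. Compound 3 is estimated at 2500 nM, with an expected range from 500 nM to 10000 nM.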

Compound 3, half-maximal inhibitory concentration: 12700 nM
Estimate against measurement, compound 3: 5.1-fold (0.71 log units) below; the whole stated range lies below it.
By their numbers in this assay, from the lowest: compounds 2, 1 and 3 (each within the scatter of the next).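

Replacing fluoro with (trifluoromethyl)sulfanyl on this aromatic carbon, para to a large group, gives a 1.5-fold higher number from compound 2 to compound 3 (0.18 log units; within the scatter) in this assay and so leaves the two compounds level. At this position, then, a group of 5 heavy atoms reads the same as one of a single heavy atom. No measurement shown here accounts for this result.

From the compounds shown here alone, whether an amine, a carboxylic acid or a longer chain at this place would read differently remains open. So does whether any group here can move the number beyond the scatter.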